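Ring swap at the chain end, compound 2 to compound 3

The source may report more compounds than this note shows. Statements on the series, on what has been measured and on what is new or still open speak of the compounds shown alone.

Measured so far:
compound 1 `Cc1cc(OCCCCCCC[N+]23CCN(CC2)CC3)cc(-n2cc(C(=O)Nc3cc(F)cc(F)c3)c(=O)c3ccc(N(C)C)nc32)c1`: 10.3%
compound 2 `CC[N+]1(CCCCCCCOc2cc(C)cc(-n3cc(C(=O)Nc4cc(F)cc(F)c4)c(=O)c4ccc(N(C)C)nc43)c2)CCCCC1`: 67.2%

In an assay on LX2 cells for inhibition of COL1A1 promoter (Homo sapiens), read by a luciferase reporter, with a stated time of 24 h, tested at 20 uM (a lower number here means a weaker effect, a higher number a stronger effect of the compound at the concentration tested), compound 2 gives 67.2%, the higher of the two values; compound 1 gives 10.3%. Among the compounds with values here, the one step available is a number 56.9 percentage points higher from compound 1 to compound 2 (beyond the scatter), and compound 2 stands at the top of this small set.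

Compound 3 `Cc1cc(OCCCCCCC[N+]2(C)CCN(C)CC2)cc(-n2cc(C(=O)Nc3cc(F)cc(F)c3)c(=O)c3ccc(N(C)C)nc32)c1` differs from compound 2 by a group of 8 heavy atoms (6 carbon, 2 nitrogen; one six-membered non-aromatic ring with 2 hetero atoms) in place of a group of 8 heavy atoms (7 carbon, 1 nitrogen; one six-membered non-aromatic ring with 1 hetero atom), on a saturated chain carbon, seven bonds along the chain from an oxygen on an aromatic ring. This restores a second ring nitrogen while keeping one ring, so it lies structurally between compound 1 and compound 2. Given the size of the step of a number 56.9 percentage points higher from compound 1 to compound 2 (beyond the scatter), a partial reversal is expected, with a drop of a number 27.2 percentage points lower from compound 2 to compound 3 (beyond the scatter). Compound 3 is therefore estimated at 40%, within 12% to 70%.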

Compound 3, a percentage reported as inhibition, at one concentration (the size of the read-out at that concentration, not a potency): 2.8%
Compound 3: the middle estimate sits 37.2 percentage points above what was measured, outside the stated range (below it).
By their numbers in this assay, from the lowest: compounds 3 and 1 (each within the scatter of the next); then compound 2.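

In this assay, keeping one ring at the chain end does not preserve the effect of compound 2: the change gives a number 64.4 percentage points lower from compound 2 to compound 3 (beyond the scatter). The second ring of compound 1 does not separate it from compound 3, with a number 7.5 percentage points lower from compound 1 to compound 3 (within the scatter), so among these three compounds only the group with 1 hetero atom, in compound 2, stands high. No measurement bears on the reason for this drop.

Compound 3 also differs from compound 2 in the alkyl group on the charged nitrogen, so the two changes remain unseparated. From the compounds shown here alone, how a morpholine ring or a pyrrolidine ring at this chain end would read out remains open.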